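Acyclic hydroxy-bearing groups in place of the pyrazolyl amide

This account rests on a few compounds, and the source may have more. Where it says the series, first, only, none or still open, it means among the compounds named here.

Among the measured compounds shown here, compound 1 `CC1(C)Cc2c(sc(NC(=O)c3cn[nH]c3)c2C(N)=O)C(C)(C)O1` gives 125 nM in an assay on cells for positive allosteric modulation of Cystic fibrosis transmembrane conductance regulator variant F508del (Homo sapiens), with stated times of 10 min and 7 s, in the presence of a further agent that is not named here (on this read-out higher numbers stand for an effect only at larger amounts of compound and lower numbers for an effect already at smaller amounts), the highest of the two numbers measured so far; the nearest is compound 2 `CC1(C)Cc2c(sc(NC(=O)C(C)(C)O)c2C(N)=O)C(C)(C)O1`, which in this assay gives 16 nM. That single measured step, a 7.8-fold lower number from compound 1 to compound 2 (0.89 log units; beyond the scatter), alters the same position that compound 3 `CC(C)(C)CC(O)C(=O)Nc1sc2c(c1C(N)=O)CC(C)(C)OC2(C)C` alters: a group of 7 heavy atoms (6 carbon, 1 oxygen; no ring) in place of a group of 5 heavy atoms (3 carbon, 2 nitrogen; one five-membered aromatic ring with 2 hetero atoms), on a carbonyl carbon. For the measured compounds named here, the group entering in compound 3 again brings one hydrogen-bond donor and no ring, as did the group entering in compound 2, so the step from compound 1 to compound 2 is the one comparison that bears on it. A lowering of comparable size is therefore expected, though the larger entering group need not reproduce it fully; the estimated step is a 4.2-fold lower number from compound 1 to compound 3 (0.62 log units; beyond the scatter). Compound 3 is expected to give about 30 nM in this assay, with an estimated range from 10 nM to 100 nM.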

Compound 3, half-maximal effective concentration: 0.54 nM
Compound 3: middle estimate off by 56-fold (1.74 log units), on the high side; measured number outside the range, below it.
By their numbers in this assay, from the lowest: compound 3; then compound 2; then compound 1.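

Among acyclic groups on this carbonyl carbon, matching hydrogen-bond donor counts and the absence of a ring do not settle the result in this assay: the group of 7 heavy atoms gives a 30-fold lower number from compound 2 to compound 3 (1.47 log units; beyond the scatter) relative to the 1-hydroxy-1-methylethyl group. The larger entering group therefore goes with a much bigger change from the 1H-pyrazol-4-yl amide, a 230-fold lower number from compound 1 to compound 3 (2.36 log units; beyond the scatter), so the first replacement did not mark the extent of what this position allows. Nothing at hand gives a reason for this difference.

As far as these compounds go, what an amine in place of the hydroxy group would give remains open, so the part played by the hydroxy group itself cannot be judged. From the compounds shown here alone, it is also open whether a longer chain would lower the number further or reverse the trend.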